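The source may hold more compounds than are shown below. What is called first, only, known or untested is meant among the compounds shown, and "the series" means these compounds.

For the measured compounds named here, compound 1, `CCn1nc(-c2ccccn2)c2sccc2c1=O`, is the weaker-looking of the two compounds measured so far. Going by the values given here, in an assay on CHO cells for displacement of a labelled ligand from adenosine receptor A3 (Homo sapiens), read by scintillation counting, with a stated time of 120 min, tested at 1 uM (a higher number here means more inhibition at the concentration tested (going by the name of the read-out), a lower number less inhibition), compound 1 gives 1%, while compound 2, `CC(C)n1nc(-c2ccccn2)c2sccc2c1=O`, gives 2%, and the only step between measured compounds, a number 1 percentage points higher from compound 1 to compound 2 (within the scatter), is a change of the ethyl group on the ring nitrogen that leaves the inhibition essentially where it was. Compound 1 therefore stands lowest of the two numbers, with compound 2 nearest and within the scatter of it.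

Compound 3, `CCn1nc(-c2cccs2)c2sccc2c1=O`, differs from compound 1 in a single place: thiophen-2-yl in place of pyridin-2-yl on an aromatic carbon. No measured step touches this position; the one step shown concerns the chain on the ring nitrogen and was itself within the scatter. There is thus no basis in the measured pairs for expecting a change beyond the scatter, and both measured compounds sit close to the bottom of the read-out. Compound 3 is therefore expected to remain near that floor, with a step of about a number 3 percentage points higher from compound 1 to compound 3 (within the scatter), and its value in this assay is estimated at 4%, within a range from 0% to 18%.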

Compound 3, a percentage reported as inhibition, at one concentration (the size of the read-out at that concentration, not a potency): 1%
Estimate against measurement, compound 3: 3 percentage points above; low and high end bracket the measured number.
By their numbers in this assay, from the lowest: compounds 1, 3 and 2 (each within the scatter of the next).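

In this assay, the only measured change at this position among the compounds shown, thiophen-2-yl in place of pyridin-2-yl, comes to no change at the digits printed from compound 1 to compound 3 (within the scatter). For the compounds shown here, the position on the aromatic carbon next to the ring nitrogen thus takes a five-membered aromatic ring with sulfur in place of a six-membered aromatic ring with nitrogen without any shift in the number, but compound 1 at 1% and compound 3 at 1% both lie at the very bottom of the read-out, so this shows only that the swap does not lift inhibition at the concentration tested, not that the position is indifferent to what it carries. Nothing measured here gives a reason for the absence of a change.

On these data alone, whether a phenyl ring, a ring bearing an amine or a carboxylic acid at this position would raise the inhibition remains open, as does the effect of a longer chain such as butyl on the ring nitrogen. A single concentration also leaves open whether any of these compounds has measurable potency at this receptor.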